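Compound 3: methyl in place of tert-butyl

A few compounds are considered here, and "the series" means these few. Any claim that something is new, unique, unknown or untested is made for them only; others in the source may bear on it.

- compound 1 `CC(C)(C)c1ccc(NC(=O)Nc2ccc(OC[C@@]3(C)Cn4cc([N+](=O)[O-])nc4O3)cc2)cc1`: < 1 ug/mL
- compound 2 `C[C@]1(COc2ccc(N3CCN(S(=O)(=O)c4ccc(C(F)(F)F)cc4)CC3)cc2)Cn2cc([N+](=O)[O-])nc2O1`: < 1 ug/mL

In a physicochemical assay for solubility, read by HPLC, with a stated time of 4 h, at pH 7 (a lower number here means a less soluble compound, a higher number a more soluble compound), compound 1 gives < 1 ug/mL, which is a limit of the assay and not a number. Compound 2 gives < 1 ug/mL, also a limit. Compound 1 therefore stands at the limit of < 1 ug/mL in this assay, at which 2 of the 2 values shown sit.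

Compound 3 `Cc1ccc(NC(=O)Nc2ccc(OC[C@@]3(C)Cn4cc([N+](=O)[O-])nc4O3)cc2)cc1` carries methyl in place of tert-butyl on an aromatic carbon, para to a large group (methyl in place of tert-butyl on an aromatic carbon). No measured step sizes this change. The step expected in this assay is a number no lower from compound 1 to compound 3 (the limit leaves the size open), small and upward if it can be seen at all. For compound 3 the estimated solubility is 1 ug/mL, with an expected range of 0.4 ug/mL to 3 ug/mL.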

Compound 3, solubility: < 1 ug/mL
Compound 3: only a limit was reported (the forecaster's own chance of this, stated with the estimate: 65%); the middle value sits exactly at the limit.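

No step can be read from compound 1 to compound 3 in this assay, since both results are limits of the assay and not numbers. The compounds shown leave open how far methyl in place of tert-butyl moves solubility, and where any of the three truly stands: the limit of < 1 ug/mL in this assay, at which 3 of the 3 values shown sit.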